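Swapping Thiophene for Furan on a Weakly Active Core

The compounds below may be only part of what the source reports. "The series", "measured", "known", "first", "only" and "open" are said of these compounds alone.

Compound 1 `Oc1cccc(-c2cc(-c3ccsc3)cc(-c3cccc(O)c3)n2)c1` carries two 3-hydroxyphenyl groups and a thiophen-3-yl group on a shared core. Within the data shown here, in an assay on isolated protein for inhibition of DNA topoisomerase 1 (Homo sapiens), with a stated time of 30 min, tested at 20 uM (on this read-out higher numbers stand for a stronger effect at the one concentration tested and lower numbers for a weaker effect), compound 1 gives 4.5%, a read-out that sits near the bottom of the scale and is the only number in this small set. Compound 2 `Oc1ccc(-c2cc(-c3ccsc3)cc(-c3cccc(O)c3)n2)cc1` is a close relative of compound 1; in this assay compound 2 gives "not determined" (no result reported), so it adds no number to compare against and compound 1 stands alone. Compound 3 `Oc1cccc(-c2cc(-c3ccoc3)cc(-c3cccc(O)c3)n2)c1` has not been measured yet. It differs from compound 1 in a single place: furan-3-yl in place of thiophen-3-yl on an aromatic carbon. The two five-membered rings match in size, in count of hetero atoms and in donor and acceptor count, and nothing in the data points either way. Among the measured compounds shown here, with no measured step to lean on, the step in this assay is expected to stay within the usual scatter, a number 0.5 percentage points higher from compound 1 to compound 3 (within the scatter). Compound 3 is therefore estimated at 5% in this assay, within a range from -5% to 16%.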

Compound 3, a percentage reported as inhibition, at one concentration (the size of the read-out at that concentration, not a potency): 2%
Beside the measured number, compound 3's estimate is 3 percentage points above it; measured number inside the range.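

In this assay, replacing thiophen-3-yl with furan-3-yl on the aromatic carbon opposite the ring nitrogen gives a number 2.5 percentage points lower from compound 1 to compound 3 (within the scatter), so this read-out does not separate the two five-membered rings. Among these compounds, this is the first measured step at this position, and it shows that exchanging the sulfur of the ring for oxygen, with ring size and the counted donors and acceptors unchanged, produces no difference that can be told from ordinary repeat variation. Nothing measured here explains why the two rings read alike, and a single step within the scatter offers no trend to interpret.

Both compounds carry a five-membered aromatic ring with one hetero atom at this position, so they say little about how a group of another kind would behave there, such as an amine, a carboxylic acid or a longer alkyl chain. As far as these compounds go, it also remains open whether any such group could lift the read-out clear of the scatter, or whether thiophen-3-yl and furan-3-yl would still read alike on a version of the shared core with a stronger effect.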